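Removing One Methoxy Group From a Chalcone-Pyrazole Series

This account rests on a few compounds, and the source may have more. Where it says the series, first, only, none or still open, it means among the compounds named here.

Three compounds sharing a core of a pyrazole linked through an unsaturated ketone to an aromatic ring have been tested in a functional assay on HCT-116 cells (Homo sapiens) for inhibition, read by sulforhodamine B assay, with a stated time of 48 h; a lower number here means a stronger inhibitor of growth, a higher number a weaker inhibitor of growth. Compound 1 `COc1ccc(-c2cc(/C=C/C(=O)c3ccc(N)cc3)[nH]n2)cc1` gives 3610 nM. Compound 2 `COc1ccc(-c2cc(/C=C/C(=O)c3ccc(N)cc3)[nH]n2)cc1OC` gives 3510 nM. Compound 3 `COc1cc(C(=O)/C=C/c2cc(-c3cc(OC)c(OC)c(OC)c3)n[nH]2)cc(OC)c1OC` gives 2590 nM; these three values all sit within the usual scatter of one another, so no order among them can be claimed.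

Compounds 2 and 1 differ in one place, (hydrogen in place of methoxy on an aromatic carbon), and the step is a 1.0-fold higher number from compound 2 to compound 1 (0.01 log units; within the scatter). The difference between the core of compound 2 and the core of compound 3 is not broken down here.

Compound 4 `COc1ccc(-c2cc(/C=C/C(=O)c3cc(OC)c(OC)c(OC)c3)[nH]n2)cc1OC` has not yet been measured. It differs from compound 3 by hydrogen in place of methoxy on an aromatic carbon. This is the same kind of change as that from compound 2 to compound 1, not the same one: in compound 4 the place is also meta to a methoxy group, which it is not in compound 1. Because the measured step of a 1.0-fold higher number from compound 2 to compound 1 (0.01 log units; within the scatter) lies within the scatter, the expected step here is also a small one, a 1.0-fold higher number from compound 3 to compound 4 (0.02 log units; within the scatter), resting only on that single example. Compound 4 is therefore expected to give about 2700 nM in this assay. For compound 4 the expected range runs from 1300 nM to 5600 nM.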

Compound 4, concentration for total growth inhibition: 1790 nM
Compound 4: middle estimate off by 1.5-fold (0.18 log units), on the high side, and the stated range covers the measured number.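

In this assay the new step is a 1.4-fold lower number from compound 3 to compound 4 (0.16 log units; within the scatter), so removing this methoxy group leaves the number within the usual scatter on this core as well. Set side by side, the two examples of the same change cannot be told apart: the same change on two cores in this assay, a 1.0-fold higher number (0.01 log units; within the scatter) from compound 2 to compound 1 and a 1.4-fold lower number (0.16 log units; within the scatter) from compound 3 to compound 4, 1.5-fold (0.17 log units) apart, within the scatter of two such steps. This shows that, in these two pairs, replacing methoxy with hydrogen gave no step beyond the scatter on either core, but two pairs are a thin basis. The place is not quite the same in both: only in compound 4 is it meta to a methoxy group. None of this shows that the change would be as small on any further core.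

The compounds shown carry only methoxy or hydrogen at this place, so it remains open what a fluorine atom, a hydroxyl group or a longer chain such as ethoxy would do there. As far as these compounds go, it also remains open whether removing a methoxy group at other places on these compounds would give an equally small step.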